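The compounds below may be only part of what the source reports. "The series", "measured", "known", "first", "only" and "open" are said of these compounds alone.

- Compound 1 `CNc1cc(-c2ccc3cnn(Cc4cc(OC)cc(OC)c4)c3c2)cn(C)c1=O`: 8600 nM
- Compound 2 `CNc1cc(-c2ccc3cnn(Cc4ccc(F)c(F)c4)c3c2)cn(C)c1=O`: 8800 nM

For the measured compounds named here, in a functional assay on BT-474 cells (Homo sapiens) for antiproliferative activity (a lower number here means a stronger inhibitor, a higher number a weaker inhibitor), compound 2 gives 8800 nM, level with the only other measured number. Compound 3 `CNc1cc(-c2ccc3cnn(Cc4ccc(F)c([N+](=O)[O-])c4)c3c2)cn(C)c1=O` differs from it by nitro in place of fluoro on an aromatic carbon. Going by the values given here, the one measured step bearing on this is a 1.0-fold higher number from compound 1 to compound 2 (0.01 log units; within the scatter), where 3,4-difluorophenyl replaced 3,5-dimethoxyphenyl. Among the compounds with values here, no nitro compound has been measured, so this small step is only a weak guide. The expected step, none beyond the scatter, is a 1.1-fold lower number from compound 2 to compound 3 (0.04 log units; within the scatter). For compound 3 the estimated value is 8000 nM, with an expected range of 3500 nM to 18000 nM.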

Compound 3, half-maximal inhibitory concentration: 6500 nM
Compound 3: the middle estimate sits 1.2-fold (0.09 log units) above what was measured, and the stated range covers the measured number.
By their numbers in this assay, from the lowest: compounds 3, 1 and 2 (each within the scatter of the next).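

In this assay, nitro in place of fluoro on this aromatic carbon gives a 1.4-fold lower number from compound 2 to compound 3 (0.13 log units; within the scatter) and so stays within the scatter, even though three heavy atoms replace one. Replacing 3,5-dimethoxyphenyl with 4-fluoro-3-nitrophenyl gives a 1.3-fold lower number from compound 1 to compound 3 (0.12 log units; within the scatter) and also stays within the scatter, so all three aromatic groups read alike here. Nothing available explains this sameness.

On these data alone, whether an amine or a carboxylic acid at this position would read differently remains open. So does whether any change on this ring can move the number beyond the scatter.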